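Dropping a Methoxy Group from a Weak Carboxylic Acid

The source may report more compounds than this note shows. Statements on the series, on what has been measured and on what is new or still open speak of the compounds shown alone.

Compound 1, `C=CC1=C(C(=O)Nc2ccc(C)cc2)C(c2ccc(OC)cc2)OC1`, gives > 100000 nM in a functional assay on QGY7701 cells (Homo sapiens) for cytotoxicity, read by MTT assay, with a stated time of 24 h (a lower number here means a stronger inhibitor, a higher number a weaker inhibitor), a limit of the assay rather than a number.
Compound 2, `C=CC1=C(C(=O)NCC(C)C)C(c2ccc(OC)cc2)OC1`, gives > 100000 nM in this assay, again only a limit.
Compound 3, `C=CC1=C(C(=O)O)C(c2ccc(OC)c(OC)c2)OC1`, gives > 100000 nM in this assay, also a limit.

Compound 3 therefore stands at the edge of what the assay can report, together with the other two values; all three sit at the limit of > 100000 nM in this assay, at which 3 of the 3 values shown sit. Among the compounds with values here, the one measured step, a step that the two limits leave unreadable from compound 1 to compound 2, cannot be read because both of its ends are limits. Compound 4, `C=CC1=C(C(=O)O)C(c2ccc(OC)cc2)OC1`, differs from compound 3 in a single place: hydrogen in place of methoxy on an aromatic carbon. Within the data shown here, no measured step bears on this change, so no direction can be argued from the data. The expected step of a number no higher from compound 3 to compound 4 (the limit leaves the size open) in this assay is accordingly none beyond the scatter. Compound 4 is estimated at 100000 nM, with a range from 30000 nM to 300000 nM, and will most likely again be reported only as a limit.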

Compound 4, half-maximal inhibitory concentration: > 100000 nM
Compound 4 gave a limit, no number; the forecaster's own chance of this, stated with the estimate: 85%; the middle value lies on the limit itself.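

Compound 4 gives only a limit, as do compound 1, compound 2 and compound 3, so no step among these compounds can be read. They leave open how strongly any of them acts and whether the methoxy group matters.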